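Removing the amine from the pendant phenyl of compound 2

The source may report more compounds than this note shows. Statements on the series, on what has been measured and on what is new or still open speak of the compounds shown alone.

Three compounds of the series carry a read-out in an assay on isolated protein for inhibition of ubiquitin carboxyl-terminal hydrolase 7 (Homo sapiens), with stated times of 30 min and 2 h; on this read-out lower numbers stand for stronger inhibition and higher numbers for weaker inhibition. For the measured compounds named here, compound 1 `Cn1nc2c(=O)n(CC3(O)CCN(Cc4ccc(-c5ccncc5)cc4Cl)CC3)cnc2c1-c1ccc(CN)cc1` gives 257 nM and compound 3 `Cn1nc2c(=O)n(CC3(O)CCN(Cc4ccc(-n5ccnc5)cc4Cl)CC3)cnc2c1-c1ccc(CN)cc1` gives 228 nM; the only single-point step among them, a 1.1-fold lower number from compound 1 to compound 3 (0.05 log units; within the scatter), is a change on the far aryl group and says nothing about the pendant phenyl. Compound 2 `Cn1nc2c(=O)n(CC3(O)CCN(Cc4ccc(-c5ccco5)cc4Cl)CC3)cnc2c1-c1ccc(C2(N)CC2)cc1` gives 66.1 nM, the lowest of the three numbers, and its gaps to compound 3 and to compound 1 both lie beyond the scatter, though compound 2 differs from each of them in more than one place.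

Compound 4 `Cn1nc2c(=O)n(CC3(O)CCN(Cc4ccc(-c5ccco5)cc4Cl)CC3)cnc2c1-c1ccc(F)cc1` is compound 2 with fluoro in place of 1-aminocyclopropyl on an aromatic carbon. Going by the values given here, no measured pair isolates this change: nothing shows the pendant phenyl without a nitrogen-bearing substituent, and the difference between the aminomethyl of compounds 1 and 3 and the 1-aminocyclopropyl of compound 2 is confounded with the change on the far aryl group. The expectation therefore rests on the structural change alone, and a step to a higher number, a 6.1-fold higher number from compound 2 to compound 4 (0.78 log units; beyond the scatter), is expected rather than one within the scatter. Compound 4 is estimated at 400 nM in this assay, with a range from 120 nM to 1500 nM.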

Compound 4, half-maximal inhibitory concentration: 64.5 nM
Beside the measured number, compound 4's estimate is 6.2-fold (0.79 log units) above it; measured number outside the range, below it.
By their numbers in this assay, from the lowest: compounds 4 and 2 (each within the scatter of the next); then compounds 3 and 1 (each within the scatter of the next).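

With the far aryl group and the rest of compound 2 held fixed, a 1.0-fold lower number from compound 2 to compound 4 (0.01 log units; within the scatter) in this assay, so this para position on the pendant phenyl accepts either group without a change beyond the scatter. The read-out therefore does not depend here on a nitrogen-bearing substituent at this position: the exchange removes the three-membered carbon ring together with the hydrogen-bond donor and acceptor counted for 1-aminocyclopropyl, and 4-fluorophenyl reads the same as 4-(1-aminocyclopropyl)phenyl within the scatter. No measurement at hand accounts for this equivalence.

For the compounds shown here, the pair covers only one far aryl group, so it remains open whether the same exchange would also stay within the scatter from the aminomethyl compounds with pyridin-4-yl or 1H-imidazol-1-yl on that far ring. Also open, as far as these compounds go, is how this position responds to other replacements, such as hydrogen, a methoxy group, a carboxylic acid or a longer aminoalkyl chain, any of which could show whether the flat response extends beyond these two substituents.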